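A few compounds are considered here, and "the series" means these few. Any claim that something is new, unique, unknown or untested is made for them only; others in the source may bear on it.

Working notes on a series of bile acid receptor ligands sharing one core. The compounds were measured in an assay on isolated protein for inhibition of Bile acid receptor (Homo sapiens), read by TR-FRET and LanthaScreen; on this read-out higher numbers stand for weaker inhibition and lower numbers for stronger inhibition.

Compound 1 `COc1ccc(Oc2ccc(N3CC(=O)N([C@@H](CC(C)C)c4nc5ccc(C(=O)O)cc5n4C)C3=O)cc2)cc1` gives 75300 nM in this assay. Compound 2 `C[C@@H](c1nc2ccc(C(=O)O)cc2n1C)N1C(=O)CN(c2ccc(Oc3ccccc3)cc2)C1=O` gives 10400 nM in this assay, and compound 3 `CC(C)C[C@@H](c1nc2ccc(C(=O)O)cc2n1C)N1C(=O)CN(c2cccc(Oc3ccccc3)c2)C1=O` gives 18200 nM in this assay. On these three numbers compound 1 stands highest; its nearest neighbour is compound 3, whose number is lower by more than the scatter, and its furthest is compound 2, whose number is lower still, also beyond the scatter. No two of these compounds differ in only one place, so no single-point step between measured compounds is available.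

Compound 4 `CC(C)C[C@@H](c1nc2ccc(C(=O)O)cc2n1C)N1C(=O)CN(c2ccc(Oc3ccc(Cl)cc3)cc2)C1=O` is not yet measured in this assay. Relative to compound 1 it carries one change: chloro in place of methoxy on an aromatic carbon. Compounds 2 and 3, which lack the methoxy group, both sit below compound 1, so removal of the methoxy in favour of chloro is expected to move the number downward, toward stronger inhibition, by a step of a 3.4-fold lower number from compound 1 to compound 4 (0.53 log units; beyond the scatter) that lies beyond the scatter. For compound 4 the expected value in this assay is 22000 nM, with a range from 7000 nM to 70000 nM.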

Compound 4, half-maximal inhibitory concentration: 2560 nM
Compound 4: the middle estimate sits 8.6-fold (0.93 log units) above what was measured; measured number outside the range, below it.
By their numbers in this assay, from the lowest: compound 4; then compounds 2 and 3 (each within the scatter of the next); then compound 1.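

In this assay the exchange of methoxy for chloro gives a 29-fold lower number from compound 1 to compound 4 (1.47 log units; beyond the scatter), a large step beyond the scatter and the first single-point step available in this series. It shows that this position, on an aromatic carbon para to a large group, is not a silent one: with the rest of compound 1 unchanged, replacing 4-methoxyphenoxy with 4-chlorophenoxy is enough to move the number well past the usual scatter, toward stronger inhibition. Nothing measured here accounts for the size of this step.

From the compounds shown here alone, with only methoxy and chloro compared at this position, the step cannot yet be divided between the departure of methoxy and the arrival of chloro, and it remains open where hydrogen, fluoro, bromo, methyl, trifluoromethyl or a nitrile would fall on the same scaffold. Going by these compounds, it also remains open whether the same exchange would give a step of similar size with a different side chain on the shared core, or with the phenoxy group attached elsewhere on its ring.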